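The source may hold more compounds than are shown below. What is called first, only, known or untested is meant among the compounds shown, and "the series" means these compounds.

Measured compounds:
compound 1 `CC(C)(C)[C@H]1C(O)=C(C2=C(C(N)=O)S(=O)(=O)c3cc(NS(C)(=O)=O)ccc3N2)C(=O)N1Cc1ccc(F)cc1` — > 50000 nM
compound 2 `CC(C)(C)CCN1C(=O)C(C2=CS(=O)(=O)c3cc(NS(C)(=O)=O)ccc3N2)=C(O)[C@@H]1C(C)(C)C` — > 50000 nM
compound 3 `CC(C)(C)[C@H]1C(O)=C(C2=C(Cl)S(=O)(=O)c3cc(NS(C)(=O)=O)ccc3N2)C(=O)N1Cc1ccc(F)cc1` — > 50000 nM

In an ADME assay on 2209-23 cells (Homo sapiens) for cytotoxicity, read by WST assay and thymidine incorporation (a higher number here means that more compound is tolerated, a lower number that less compound is tolerated), compound 1 gives > 50000 nM, which is a limit of the assay and not a number. Compound 2 gives > 50000 nM, again a limit. Compound 3 gives > 50000 nM, also a limit. Within the data shown here, the single step between compounds that differ in one place, a step that the two limits leave unreadable from compound 1 to compound 3, is therefore not readable. The evidence reads: the limit of > 50000 nM in this assay, at which 3 of the 3 values shown sit. Compound 2 stands at the same limit as the other two, with no number to place it more closely.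

Compound 4 `COc1cc(CN2C(=O)C(C3=CS(=O)(=O)c4cc(NS(C)(=O)=O)ccc4N3)=C(O)[C@@H]2C(C)(C)C)ccc1F` differs from compound 2 as follows: 4-fluoro-3-methoxyphenyl in place of neopentyl on a saturated chain carbon bound to an amide-type nitrogen in a ring. Among the measured compounds shown here, no measured pair covers this change, and the only measured step, from carbamoyl to chloro, gives no size. Everything shown sits at the limit, so compound 4 is expected to behave the same way in this assay, with a step of a number no higher from compound 2 to compound 4 (the limit leaves the size open) from compound 2 that is expected to be nothing beyond the scatter. The estimate for compound 4 is 50000 nM, with an expected range from 25000 nM to 100000 nM.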

Compound 4, half-maximal cytotoxic concentration: > 50000 nM
Compound 4: a limit, no number; the forecaster's own chance of this, stated with the estimate: 85%; the middle value sits exactly at the limit.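

In this assay compound 4 gives > 50000 nM as a limit and not a number. Compound 2 stands at the same limit, so no step can be read from compound 2 to compound 4. The compounds shown leave open what concentration, if any, would prove cytotoxic for this series.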